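Chloro for hydrogen on a fused two-ring core

The compounds below may be only part of what the source reports. "The series", "measured", "known", "first", "only" and "open" are said of these compounds alone.

Measured compounds:
compound 1 `ClCc1ccccc1Cn1cnc2c(Cl)nc(Cl)nc21` — 5240 nM
compound 2 `ClCc1ccccc1Cn1cnc2c(Cl)ncnc21` — 28200 nM
compound 3 `ClCc1cccc(Cn2cnc3c(Cl)ncnc32)c1` — 6310 nM

In a functional assay on UACC-62 cells (Homo sapiens) for cytotoxicity, read by sulforhodamine B assay, with a stated time of 48 h (a higher number here means that more compound is tolerated, a lower number that less compound is tolerated), compound 2 gives 28200 nM, and compound 1 gives 5240 nM. Among the measured compounds shown here, the one change between them, (chloro in place of hydrogen on an aromatic carbon), made a step of a 5.4-fold lower number from compound 2 to compound 1 (0.73 log units; beyond the scatter). Compound 3 gives 6310 nM in this assay; it shares its atoms with compound 2, but the difference between the two cores is not broken down here, so only the two values can be set side by side.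

Compound 4 `ClCc1cccc(Cn2cnc3c(Cl)nc(Cl)nc32)c1` has not yet been measured. For the measured compounds named here, it arises from compound 3 by chloro in place of hydrogen on an aromatic carbon, the same change, at a place described in the same words, as the one from compound 2 to compound 1. Because that earlier change gave a 5.4-fold lower number from compound 2 to compound 1 (0.73 log units; beyond the scatter), a step of similar size from compound 3 is expected, namely a 4.5-fold lower number from compound 3 to compound 4 (0.65 log units; beyond the scatter) in this assay, with the caution that one prior example is a thin base. Compound 4 is therefore estimated at 1400 nM in this assay, expected to lie between 500 nM and 4000 nM.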

Compound 4, concentration lethal to 50% of the cells: 6450 nM
Beside the measured number, compound 4's estimate is 4.6-fold (0.66 log units) below it; the measured number lies above the stated range.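

In this assay, chloro in place of hydrogen on an aromatic carbon, between two ring nitrogen atoms, gives a 1.0-fold higher number from compound 3 to compound 4 (0.01 log units; within the scatter), so compound 3 and compound 4 stand within the scatter of each other. The step seen on the core of compound 2 therefore does not carry over to the core of compound 3, and the same change cannot be treated as a fixed increment in this series: the same change on two cores in this assay, a 5.4-fold lower number (0.73 log units; beyond the scatter) from compound 2 to compound 1 and a 1.0-fold higher number (0.01 log units; within the scatter) from compound 3 to compound 4, 5.5-fold (0.74 log units) apart, beyond the scatter of two such steps

This shows only that the outcome of the change depends on the core in these two pairs; it does not show what in the two cores accounts for the gap, nor which outcome another core in the series would follow. The compounds shown leave open how an amine or a methoxy group on that same aromatic carbon would read on each of the two cores. They also leave open whether bromo would part the two cores in the way chloro does.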